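One More Methoxy Group on a Shared Core

A few compounds are considered here, and "the series" means these few. Any claim that something is new, unique, unknown or untested is made for them only; others in the source may bear on it.

Measured so far:
compound 1 `COc1ccc(-c2cc(/C=C/C(=O)c3ccc(N)cc3)[nH]n2)cc1` gives 97%
compound 2 `COc1ccc(C(=O)/C=C/c2cc(-c3cc(OC)c(OC)c(OC)c3)n[nH]2)cc1OC` gives 92%
compound 3 `COc1ccc(-c2cc(/C=C/C(=O)c3ccc(N)cc3)[nH]n2)cc1OC` gives 104%

All three values come from a functional assay on KM12 cells (Homo sapiens) for cytotoxicity, read by sulforhodamine B assay, with a stated time of 48 h, tested at 0.1 uM; on this read-out higher numbers stand for a weaker effect at the one concentration tested and lower numbers for a stronger effect. Compound 1 and compound 3 differ in one place, (methoxy in place of hydrogen on an aromatic carbon), and this change gave a number 7 percentage points higher from compound 1 to compound 3 (within the scatter). Compound 2 stands on a different core; the difference between the cores of compound 1 and compound 2 is not broken down here.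

Compound 4 `COc1cc(C(=O)/C=C/c2cc(-c3cc(OC)c(OC)c(OC)c3)n[nH]2)cc(OC)c1OC` is made from compound 2 by methoxy in place of hydrogen on an aromatic carbon. The surroundings are not identical, since here the entering group is also meta to a methoxy group, so this is the same kind of change rather than the same change. Resting on the step seen between compound 1 and compound 3, the step from compound 2 to compound 4 is expected to be a number 5 percentage points higher from compound 2 to compound 4 (within the scatter) in this assay. Compound 4 is therefore estimated at 97%, between 85% and 110%.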

Compound 4, a percentage reported as activity, at one concentration (the size of the read-out at that concentration, not a potency): 103%
Compound 4: the middle estimate sits 6 percentage points below what was measured; low and high end bracket the measured number.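

In this assay, methoxy in place of hydrogen on an aromatic carbon gives a number 11 percentage points higher from compound 2 to compound 4 (beyond the scatter), and this step can be set beside the one seen on the other core: the same change on two cores in this assay, a number 7 percentage points higher (within the scatter) from compound 1 to compound 3 and a number 11 percentage points higher (beyond the scatter) from compound 2 to compound 4, 4 percentage points apart, within the scatter of two such steps. The two steps point the same way and cannot be told apart in size, so on these two cores the change carries over. Two pairs tested at one concentration do not make a rule for other cores, and they do not show how the change would behave at other concentrations.

The compounds shown leave open what a hydroxyl group or a chlorine atom would do in place of this methoxy group. They also leave open whether any such change could bring the number down.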